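The compounds below may be only part of what the source reports. "The series", "measured", "known", "first", "only" and "open" are said of these compounds alone.

Measured compounds:
- compound 1, `CCCCCn1c(=O)c2c(ncn2C2O[C@H](C(=O)NC)[C@@H](O)[C@H]2O)n(CCCCC)c1=O`: 2630 nM
- compound 2, `CCCCCCn1c(=O)c2c(ncn2C2O[C@H](CO)[C@@H](O)[C@H]2O)n(CCCCCC)c1=O`: 43000 nM

Among the compounds with values here, in an assay on CHO cells for displacement of a labelled ligand from adenosine receptor A3 (Rattus norvegicus) (on this read-out lower numbers stand for stronger inhibition and higher numbers for weaker inhibition), compound 1 gives 2630 nM and stands lowest of the two numbers; compound 2 gives 43000 nM, a gap beyond the scatter, but the two structures differ in more than one place, so their values show only that compound 1 is the stronger of the pair. The unmeasured compound 3, `CCCCCn1c(=O)c2c(ncn2C2O[C@H](CO)[C@@H](O)[C@H]2O)n(CCCCC)c1=O`, keeps the pentyl chains of compound 1 and changes a single position: hydroxymethyl in place of methylcarbamoyl on a saturated ring carbon. Within the data shown here, no step between measured compounds isolates this change. Among the measured compounds shown here, the author expects a loss of affinity beyond the scatter in this assay, taking as the only guide that compound 2, which also carries hydroxymethyl, gives 43000 nM. The step from compound 1 to compound 3 is estimated as a 9.5-fold higher number from compound 1 to compound 3 (0.98 log units; beyond the scatter). For compound 3 in this assay the estimate is 25000 nM, with a range from 8000 nM to 80000 nM.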

Compound 3, inhibition constant: 4810 nM
For compound 3 the middle estimate is 5.2-fold (0.72 log units) above the measured one; measured number outside the range, below it.
By their numbers in this assay, from the lowest: compounds 1 and 3 (each within the scatter of the next); then compound 2.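

In this assay, hydroxymethyl in place of methylcarbamoyl on a saturated ring carbon gives a 1.8-fold higher number from compound 1 to compound 3 (0.26 log units; within the scatter) and, with the pentyl chains held constant, this exchange cannot be told apart from the scatter. Within the data shown here, this is the first view of this position on its own, which the earlier pair could not give, as compound 1 and compound 2 differ in more than one place; it shows that, in this series, methylcarbamoyl is not required at this position to keep the level of compound 1. Nothing in the available data offers a reason for this result.

On these data alone, whether a carboxylic acid, an amine or a longer amide such as ethylcarbamoyl would be accepted at this position remains open. So does whether the same exchange would read alike with hexyl chains on the shared core.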